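The compounds below may be only part of what the source reports. "The series", "measured", "known", "first", "only" and "open" are said of these compounds alone.

Compound 1 `CCCNC(=C\C(=O)/C=C/c1ccc(O)c(OC)c1)/C=C/c1ccc(O)c(OC)c1` gives 88% in a functional assay on Caco-2 cells (Homo sapiens), read by fluorescence, tested at 10 uM; a lower number here means a stronger effect, a higher number a weaker effect of the compound at the concentration tested.
Compound 2 `C=CCNC(=C\C(=O)/C=C/c1ccc(O)c(OC)c1)/C=C/c1ccc(O)c(OC)c1` gives 76% in this assay.
Compound 3 `COc1cc(/C=C/C(=O)/C=C(/C=C/c2ccc(O)c(OC)c2)NC2CCCCC2)ccc1O` gives 63% in this assay.

Among the three measured compounds, compound 3 has the lowest number in this assay, and both of its steps to the other compounds lie beyond the scatter, so it shows the strongest effect of the three. Compound 4 `COc1cc(/C=C/C(=O)/C=C(/C=C/c2ccc(O)c(OC)c2)NCC(C)C)ccc1O` differs from compound 3 in one place: isobutyl in place of cyclohexyl on an amine nitrogen. Among the measured compounds shown here, two measured steps bear on this change, since each put cyclohexyl in place of an open chain on the same nitrogen: a number 25 percentage points lower from compound 1 to compound 3 (beyond the scatter) and a number 13 percentage points lower from compound 2 to compound 3 (beyond the scatter). Going back from cyclohexyl to an open chain is therefore expected to move the number upward, by a modest step, a number 15 percentage points higher from compound 3 to compound 4 (beyond the scatter). Compound 4 is estimated at 78% in this assay, with a range from 62% to 94%.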

Compound 4, a percentage reported as activity, at one concentration (the size of the read-out at that concentration, not a potency): 74%
Beside the measured number, compound 4's estimate is 4 percentage points above it; the range from low to high includes it.
By their numbers in this assay, from the lowest: compound 3; then compounds 4 and 2 (each within the scatter of the next); then compound 1.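

In this assay, an open chain on this amine nitrogen can fall short of cyclohexyl even when branched (a number 11 percentage points higher from compound 3 to compound 4 (beyond the scatter)). Among the compounds shown here, the branched isobutyl also separates from the straight propyl (a number 14 percentage points lower from compound 1 to compound 4 (beyond the scatter)), but it cannot be told apart from allyl (a number 2 percentage points lower from compound 2 to compound 4 (within the scatter)), so branching is not the only change on this nitrogen that lowers the number. No measurement shown explains these differences.

As far as these compounds go, it remains open whether the ring itself or the larger size of cyclohexyl matters. Cyclopentyl or a longer chain such as hexyl on the same nitrogen could help separate the two.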